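Chain change on compound 1: working notes

The source may hold more compounds than are shown below. What is called first, only, known or untested is meant among the compounds shown, and "the series" means these compounds.

Measured in a functional assay on A549 cells (Homo sapiens) for inhibition, read by MTT assay, with a stated time of 72 h; on this read-out lower numbers stand for stronger inhibition and higher numbers for weaker inhibition:
- compound 1 `Nc1nc2cc(-c3nn(CCC(=O)NO)c4ncnc(N)c34)ccc2o1`: > 150000 nM (a limit)
- compound 2 `Nc1ncnc2c1c(-c1cnc3[nH]ccc3c1)nn2CCCCCCC(=O)NO`: 50000 nM
- compound 3 `Nc1ncnc2c1c(-c1cnc3[nH]ccc3c1)nn2CCC(=O)NO`: > 150000 nM (a limit)

Compound 1 reads > 150000 nM, which is a limit and not a number. Its standing is therefore only this: the limit of > 150000 nM in this assay, at which 2 of the 3 values shown sit.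

The change to compound 4 `CNC(=O)CCCCCCCn1nc(-c2ccc3oc(N)nc3c2)c2c(N)ncnc21` is 5-(methylcarbamoyl)pentyl in place of hydroxycarbamoyl on a saturated chain carbon, two bonds along the chain from an aromatic nitrogen. It puts 5-(methylcarbamoyl)pentyl in place of hydroxycarbamoyl on a saturated chain carbon, two bonds along the chain from an aromatic nitrogen.

Among the compounds with values here, one measured step bears on this: an at least 3.0-fold higher number from compound 2 to compound 3 (0.47 log units; beyond the scatter). That step is beyond the scatter, and it replaces 4-(hydroxycarbamoyl)butyl with hydroxycarbamoyl, so the chain change in compound 4 runs the opposite way. It was measured on a different core from that of compound 1, however, and both of its compounds keep the hydroxycarbamoyl end that compound 4 gives up. Within the data shown here, no measured step covers that exchange.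

A modest move to a lower number in this assay is therefore expected, and another limit reading remains quite possible. The expected change is an at least 2.1-fold lower number from compound 1 to compound 4 (0.33 log units; beyond the scatter). Compound 4 is estimated at 70000 nM, with an expected range of 25000 nM to 150000 nM.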

Compound 4, half-maximal inhibitory concentration: 8360 nM
For compound 4 the middle estimate is 8.4-fold (0.92 log units) above the measured one, and the stated range ends above it.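

In this assay, within the data shown here, the exchange gives an at least 17-fold lower number from compound 1 to compound 4 (1.25 log units; beyond the scatter), the first step in this set made on the core of compound 1. The earlier step kept the hydroxycarbamoyl end on both of its compounds, whereas this one shows that, at this saturated chain carbon, a measured inhibition value can be reached with a chain ending in methylcarbamoyl and no hydroxycarbamoyl group at all. The size of the step is only a bound, because the reading for compound 1 is a limit and not a number: the limit of > 150000 nM in this assay, at which 2 of the 4 values shown sit.

The change lengthens the chain and replaces its end group in one move, so the compounds shown leave open how much of the step belongs to each. The same long chain ending in hydroxycarbamoyl on the core of compound 1 would separate the two contributions, and a carboxylic acid at the end of that chain would show whether the methylcarbamoyl end matters or the chain alone carries the effect.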